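Amide nitrogen substituents on a shared diaryl ether core

The compounds below may be only part of what the source reports. "The series", "measured", "known", "first", "only" and "open" are said of these compounds alone.

Three compounds share one core and differ only in the group on the amide-type nitrogen. Compound 1 `COc1ccc(NC(=O)c2cc(Oc3ccc(/C=C/c4ccccn4)cc3)ccn2)cc1` carries a 4-methoxyphenyl there; in a functional assay on A549 cells (Homo sapiens) for antiproliferative activity, read by CCK-8 assay, with a stated time of 48 h (a lower number here means a stronger inhibitor, a higher number a weaker inhibitor), compound 1 gives 20000 nM. Compound 2 `COc1ccc(CNC(=O)c2cc(Oc3ccc(/C=C/c4ccccn4)cc3)ccn2)cc1` carries a 4-methoxybenzyl and gives 63600 nM; the change is a 3.2-fold higher number from compound 1 to compound 2 (0.50 log units; beyond the scatter). Compound 3 `CC(C)NC(=O)c1cc(Oc2ccc(/C=C/c3ccccn3)cc2)ccn1` carries an isopropyl and gives 21400 nM. Compound 3 stands second highest of the three measured compounds: a 1.1-fold higher number from compound 1 to compound 3 (0.03 log units; within the scatter), while a 3.0-fold lower number from compound 2 to compound 3 (0.47 log units; beyond the scatter).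

Compound 4 `O=C(NC1CC1)c1cc(Oc2ccc(/C=C/c3ccccn3)cc2)ccn1` is the next step: cyclopropyl in place of isopropyl on an amide-type nitrogen. Among the measured compounds shown here, no measured step swaps one small alkyl for another; the nearest evidence is that isopropyl and 4-methoxyphenyl sit within the scatter of each other in this assay, as a 1.1-fold higher number from compound 1 to compound 3 (0.03 log units; within the scatter) shows, and only the benzyl compound 2 moves beyond it. A small ring of the same heavy-atom count in place of the isopropyl is therefore expected to leave this assay essentially unchanged, with a 1.1-fold lower number from compound 3 to compound 4 (0.03 log units; within the scatter). The estimate for compound 4 is 20000 nM, with a range from 8000 nM to 50000 nM.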

Compound 4, half-maximal inhibitory concentration: 17300 nM
Beside the measured number, compound 4's estimate is 1.2-fold (0.06 log units) above it; low and high end bracket the measured number.
By their numbers in this assay, from the lowest: compounds 4, 1 and 3 (each within the scatter of the next); then compound 2.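

In this assay, closing the isopropyl into a cyclopropyl ring at the same heavy-atom count leaves the number in place (a 1.2-fold lower number from compound 3 to compound 4 (0.09 log units; within the scatter)), so the three-membered ring is tolerated on the amide-type nitrogen. Among the compounds shown here, the small ring also stays level with the 4-methoxyphenyl (a 1.2-fold lower number from compound 1 to compound 4 (0.06 log units; within the scatter)), while the 4-methoxybenzyl of compound 2 remains the one group that stands apart (a 3.7-fold lower number from compound 2 to compound 4 (0.57 log units; beyond the scatter)), leaving compound 2 as the weakest of the four and the other three unresolved from one another. Nothing available explains the separate position of compound 2 or the lack of separation among the others.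

On these data alone, whether a longer alkyl chain, a terminal amine or a carboxylic acid on this nitrogen would move the number stays open. Also open, as far as these compounds go, is whether an unsubstituted benzyl would match compound 2.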